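Methyl to chloro on the sulfonyl aryl ring

This account rests on a few compounds, and the source may have more. Where it says the series, first, only, none or still open, it means among the compounds named here.

Measured compounds:
compound 1 `CCn1cc(C(=O)O)c(=O)c2cc(F)c(N3CCN(C(=N)NS(=O)(=O)c4ccc(C)cc4)CC3)cc21` 43 nM
compound 2 `N=C(NS(=O)(=O)c1ccc(Cl)cc1)N1CCN(c2cc3c(cc2F)c(=O)c(C(=O)O)cn3C2CC2)CC1` 43 nM

In a functional assay on HL-60 cells (Homo sapiens) for antiproliferative activity, read by MTT assay, with a stated time of 72 h (a lower number here means a stronger inhibitor, a higher number a weaker inhibitor), compound 1 gives 43 nM and compound 2 gives 43 nM; the two values sit level within the scatter, so compound 1 stands alongside compound 2 with no separation to report. Compound 3 `CCn1cc(C(=O)O)c(=O)c2cc(F)c(N3CCN(C(=N)NS(=O)(=O)c4ccc(Cl)cc4)CC3)cc21` is not yet measured. It differs from compound 1 by chloro in place of methyl on an aromatic carbon. Among the compounds with values here, no step between two measured compounds isolates this change. Compound 2 already carries the chloro group and matches compound 1, so the step of a 1.0-fold higher number from compound 1 to compound 3 (0.02 log units; within the scatter) is expected to be none beyond the scatter. Compound 3 is expected to give 45 nM, with a range from 20 nM to 100 nM.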

Compound 3, half-maximal inhibitory concentration: 43 nM
Estimate against measurement, compound 3: 1.0-fold (0.02 log units) above; measured number inside the range.
By their numbers in this assay, from the lowest: compounds 1, 2 and 3 (each within the scatter of the next).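

In this assay, chloro in place of methyl on the aromatic carbon gives no change at the digits printed from compound 1 to compound 3 (within the scatter), so this swap can now be read directly with the rest of the structure held constant. With the chloro kept, ethyl in place of cyclopropyl on the aromatic nitrogen gives no change at the digits printed from compound 2 to compound 3 (within the scatter), so neither change separates these compounds. Nothing available offers an explanation for these readings.

From the compounds shown here alone, whether a methoxy group, an amine or a nitrile on the sulfonyl aryl ring would also leave the number in place remains open. So does the effect of a longer chain on the aromatic nitrogen.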